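From 2-Fluorophenyl to 2-Nitrophenyl in a Small Series

The source may hold more compounds than are shown below. What is called first, only, known or untested is meant among the compounds shown, and "the series" means these compounds.

Compound 1 `CC(=O)N1N=C(c2ccc3ccccc3c2)OC1c1cccc(Br)c1`: 2.36 ug/mL
Compound 2 `CC(=O)N1N=C(c2ccc3ccccc3c2)OC1c1ccc(Cl)cc1`: 2.48 ug/mL
Compound 3 `CC(=O)N1N=C(c2ccc3ccccc3c2)OC1c1ccccc1F`: 6.05 ug/mL

All three compounds were tested in a functional assay on B16-F10 cells (Mus musculus) for antiproliferative activity, read by MTT assay, with a stated time of 48 h; a lower number here means a stronger inhibitor, a higher number a weaker inhibitor. Compound 3 gives the highest number of the three and is the weakest inhibitor here. Between the other two there is a 1.1-fold higher number from compound 1 to compound 2 (0.02 log units; within the scatter).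

The next compound is compound 4 `CC(=O)N1N=C(c2ccc3ccccc3c2)OC1c1ccccc1[N+](=O)[O-]`, which has nitro in place of fluoro on an aromatic carbon. This turns the 2-fluorophenyl into a 2-nitrophenyl, while the shared core stays the same. Among the compounds with values here, no measured compound carries a nitro group, so the closest guides are the two steps that also change this aryl group: a 2.6-fold higher number from compound 1 to compound 3 (0.41 log units; beyond the scatter) and a 2.4-fold higher number from compound 2 to compound 3 (0.39 log units; beyond the scatter). Both are modest, and both show the 2-fluorophenyl compound with the higher number. Only these two comparisons support that pattern, and neither goes against it. A small shift toward lower numbers in this assay is therefore expected, but no step beyond the scatter. The estimated change is a 1.5-fold lower number from compound 3 to compound 4 (0.18 log units; within the scatter). Compound 4 is expected to give 4 ug/mL, with an estimated range from 1.8 ug/mL to 9 ug/mL.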

Compound 4, half-maximal inhibitory concentration: 9.01 ug/mL
Compound 4: the middle estimate sits 2.3-fold (0.35 log units) below what was measured, outside the stated range (above it).
By their numbers in this assay, from the lowest: compounds 1 and 2 (each within the scatter of the next); then compounds 3 and 4 (each within the scatter of the next).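

In this assay, nitro in place of fluoro on this aromatic carbon gives a 1.5-fold higher number from compound 3 to compound 4 (0.17 log units; within the scatter), so this series does not separate the two groups at this place on the ring, even though nitro brings more heavy atoms and two hydrogen-bond acceptors. The 2-nitrophenyl group remains clearly apart from the other two aryl groups, with a 3.6-fold higher number from compound 2 to compound 4 (0.56 log units; beyond the scatter) and a 3.8-fold higher number from compound 1 to compound 4 (0.58 log units; beyond the scatter), which adds a second compound to the earlier picture: the 2-fluorophenyl and 2-nitrophenyl compounds both give higher numbers than the 3-bromophenyl and 4-chlorophenyl compounds, and none of the four compounds goes against this. No measurement is available that explains why these two groups fall together.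

Fluoro and nitro are the only groups shown at this place on the ring, so it remains open whether an amine, a methoxy group or a carboxylic acid there would fall with compound 3 and compound 4 or with the other two. The shared core also stays the same throughout, which leaves open whether these steps would hold if the acetyl group were replaced by a longer chain.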